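Replacing a branched dialkylamino with benzyl(ethyl)amino

The compounds below may be only part of what the source reports. "The series", "measured", "known", "first", "only" and "open" are said of these compounds alone.

Of the compounds shown here, three sharing one sulfamate-bearing core have been tested in an assay on HEK293 cells for inhibition of Steryl-sulfatase (Homo sapiens), tested at 0.1 uM; on this read-out lower numbers stand for a weaker effect and higher numbers for a stronger effect at the one concentration tested. Compound 2 `CC(C)CCN(CCC(C)C)c1ccc(C(=O)N2CCc3ccc(OS(N)(=O)=O)cc3C2)cc1` gives 47%, the highest of the three numbers. Compound 3 `CCN(Cc1ccncc1)c1cccc(C(=O)N2CCc3ccc(OS(N)(=O)=O)cc3C2)c1` gives 33.3%, and compound 1 `CCN(Cc1ccc(Br)cc1)c1cccc(C(=O)N2CCc3ccc(OS(N)(=O)=O)cc3C2)c1` gives 24.2%; both stand beyond the scatter below compound 2. Within the data shown here, the single measured step, a number 9.1 percentage points higher from compound 1 to compound 3 (within the scatter), shows that exchanging the aromatic ring on the chain carbon bound to the nitrogen leaves this assay essentially unchanged.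

Compound 4 `CCN(Cc1ccccc1)c1ccc(C(=O)N2CCc3ccc(OS(N)(=O)=O)cc3C2)cc1` is not yet measured. It differs from compound 2 in one place: benzyl(ethyl)amino in place of diisopentylamino on an aromatic carbon. Among the measured compounds shown here, no measured step covers this exchange directly. Compounds 1 and 3, which also carry an ethyl group and an arylmethyl group on the nitrogen, both give lower numbers than compound 2, yet their group sits at another position on the ring, so they bear only loosely on the step. Compound 4 is therefore expected to fall somewhat below compound 2, with a number 9 percentage points lower from compound 2 to compound 4 (within the scatter). The estimate for compound 4 is 38%, in the range 22% to 52%.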

Compound 4, a percentage reported as inhibition, at one concentration (the size of the read-out at that concentration, not a potency): 66.9%
Beside the measured number, compound 4's estimate is 28.9 percentage points below it; the whole stated range lies below it.
By their numbers in this assay, from the lowest: compounds 1 and 3 (each within the scatter of the next); then compound 2; then compound 4.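

The exchange of diisopentylamino for benzyl(ethyl)amino on this aromatic carbon gives, in this assay, a number 19.9 percentage points higher from compound 2 to compound 4 (beyond the scatter). Among these compounds, the earlier compounds held no measured step at this place, so this is the first sign that the groups on this nitrogen can move the read-out beyond the scatter, and that an entering six-membered aromatic ring of carbon only is tolerated here. No measurement shown accounts for the rise.

The step changes both groups on the nitrogen at once, so the share of the benzyl group and that of the ethyl group cannot be separated. The compounds shown also leave open how a dibenzylamino group or a piperidine ring on this carbon would read at this single concentration, which gives no potency.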